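A few compounds are considered here, and "the series" means these few. Any claim that something is new, unique, unknown or untested is made for them only; others in the source may bear on it.

In a functional assay on MCF7 cells (Homo sapiens) for cytotoxicity, read by MTT assay, with a stated time of 72 h (on this read-out higher numbers stand for weaker inhibition and lower numbers for stronger inhibition), three compounds sharing one core have been measured. Compound 1 `Cc1ccnc(/C(N)=N/NC(=S)N2CCOCC2)c1` carries morpholin-4-yl on the thiocarbonyl carbon. In this assay compound 1 gives > 100000 nM, which is a limit of the assay rather than a number. Compound 2 `Cc1ccnc(/C(N)=N/NC(=S)N2CCSCC2)c1` carries thiomorpholin-4-yl in that place instead, and in this assay compound 2 gives 6900 nM. Among the compounds with values here, the step of an at least 14-fold lower number from compound 1 to compound 2 (1.16 log units; beyond the scatter) is the only measured step that changes a single place. Compound 3 `N/C(=N\NC(=S)N1CCCCC1)c1ccccn1` carries piperidin-1-yl on the thiocarbonyl carbon and no methyl on the aromatic ring, and in this assay compound 3 gives 8500 nM. Of the two numbers shown, that of compound 3 is the higher one, yet its gap to compound 2 lies within the scatter, so the two cannot be told apart.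

Compound 4 `Cc1ccnc(/C(N)=N/NC(=S)N2CCCCC2)c1` has not been measured. It differs from compound 3 by methyl in place of hydrogen on an aromatic carbon. Within the data shown here, the one measured step concerns the ring on the thiocarbonyl carbon, not the aromatic ring, so no measured step bears on this change, and no step beyond the scatter is expected in this assay. The expected step is no change at the digits printed from compound 3 to compound 4 (within the scatter). Compound 4 is therefore estimated to give 8500 nM in this assay, with a range from 4000 nM to 18000 nM.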

Compound 4, half-maximal inhibitory concentration: 18800 nM
The estimate for compound 4 lay 2.2-fold (0.34 log units) below the measured number, outside the stated range (above it).
By their numbers in this assay, from the lowest: compounds 2 and 3 (each within the scatter of the next); then compound 4. At a limit, above all of these: compound 1.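

In this assay, within the data shown here, a single methyl on the aromatic ring, opposite the ring nitrogen, is now seen to matter: a 2.2-fold higher number from compound 3 to compound 4 (0.34 log units; beyond the scatter) is the first measured change at this place, and it moves modestly towards weaker inhibition. The new compound also extends the comparison of rings on the thiocarbonyl carbon, with piperidin-1-yl giving a 2.7-fold higher number from compound 2 to compound 4 (0.44 log units; beyond the scatter) and an at least 5.3-fold lower number from compound 1 to compound 4 (0.72 log units; beyond the scatter), so that among the three rings carried with this methyl, thiomorpholin-4-yl gives the lowest number and morpholin-4-yl the highest. The last of these steps starts from a limit rather than a true number, so its real size remains unknown: the limit of > 100000 nM in this assay, at which 1 of the 4 values shown sits.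

As far as these compounds go, the effect of the methyl is known only with piperidin-1-yl on the thiocarbonyl carbon, so whether it would be the same with thiomorpholin-4-yl or morpholin-4-yl remains open. Also open, from the compounds shown here alone, is whether a chlorine atom, a methoxy group or a longer chain such as ethyl in the same place would raise the number further, leave it unchanged or lower it.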